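Removal of one aromatic chloro from compound 1

The source may hold more compounds than are shown below. What is called first, only, known or untested is meant among the compounds shown, and "the series" means these compounds.

Compound 1 `Cc1ccc(C(=O)N/N=C/c2ccc(Cl)cc2Cl)c(O)c1` gives in a functional assay (Mus musculus, strain BALB/C) for inhibition, read by MTT assay, with stated times of 24 h and 72 h (a higher number here means a weaker inhibitor, a lower number a stronger inhibitor), a value of 9780 nM, the lowest of the three numbers in hand. Compound 3 `Cc1ccc(C(=O)N/N=C/c2ccc(Cl)cc2)c(O)c1` gives 12300 nM, and the step of a 1.3-fold higher number from compound 1 to compound 3 (0.10 log units; within the scatter) involves hydrogen in place of chloro on an aromatic carbon. Going by the values given here, compound 2 `Cc1ccc(C(=O)N/N=C/c2cccc(F)c2)c(O)c1` gives 31200 nM; no single step links it to compound 1, and the two values simply sit apart.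

Compound 4 `Cc1ccc(C(=O)N/N=C/c2ccccc2Cl)c(O)c1` is not yet measured. It differs from compound 1 as follows: hydrogen in place of chloro on an aromatic carbon. Among the compounds with values here, the only measured step that bears on this is the one from compound 1 to compound 3, which also removes one chloro from the same ring and stays within the scatter. The change to compound 4 removes the other chloro instead, and nothing in hand separates the two positions. The expectation is therefore a step of a 1.2-fold higher number from compound 1 to compound 4 (0.09 log units; within the scatter), not beyond the scatter. For compound 4 the estimate in this assay is 12000 nM, within a range of 6000 nM to 25000 nM.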

Compound 4, half-maximal inhibitory concentration: 19200 nM
The estimate for compound 4 lay 1.6-fold (0.20 log units) below the measured number; measured number inside the range.
By their numbers in this assay, from the lowest: compounds 1, 3, 4 and 2 (each within the scatter of the next, the first and the last beyond it).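

In this assay, hydrogen in place of the chloro that sits meta to a chloro group and para to a large group gives a 2.0-fold higher number from compound 1 to compound 4 (0.29 log units; within the scatter) and so stays within the scatter, though near its edge. With a 1.3-fold higher number from compound 1 to compound 3 (0.10 log units; within the scatter) as the other single removal, neither chloro of compound 1 taken away alone gives a step beyond the scatter, and the two positions cannot be told apart on these numbers. No measurement in hand explains the size of this step.

Still open, as far as these compounds go, is whether removing both chloro groups together would remain within the scatter of compound 1. Also open, from the compounds shown here alone, is how an amine or a methoxy group at this position would read in this assay against the chloro and the hydrogen.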